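Heteroaryl exchange on the amine-linked chain carbon

This account rests on a few compounds, and the source may have more. Where it says the series, first, only, none or still open, it means among the compounds named here.

Going by the values given here, compound 2 `CCc1nc(C)c(CN2CCN(c3cccc4[nH]c(-c5ccc(C(C)(C)C)cc5)nc34)CC2)s1` gives 20 nM in an assay on isolated protein for displacement of a labelled ligand from Gonadotropin-releasing hormone receptor (Homo sapiens) (a higher number here means a weaker inhibitor, a lower number a stronger inhibitor), the lowest of the two numbers measured so far; its nearest neighbour is compound 1 `CCc1nc(C)c(CN2CCN(c3cccc4[nH]c(-c5ccc(C(C)(C)C)cc5)nc34)CC2)o1`, which in this assay gives 37 nM. Among the compounds with values here, the single measured step, a 1.9-fold lower number from compound 1 to compound 2 (0.27 log units; within the scatter), exchanges the oxazolyl for the thiazolyl group on the saturated chain carbon bound to an amine nitrogen in a ring, and it stays within the scatter. Compound 3 `Cc1cc(CN2CCN(c3cccc4[nH]c(-c5ccc(C(C)(C)C)cc5)nc34)CC2)nn1C` has not been measured. It differs from compound 2 by 1,5-dimethyl-1H-pyrazol-3-yl in place of 2-ethyl-4-methyl-1,3-thiazol-5-yl on a saturated chain carbon bound to an amine nitrogen in a ring. The measured step bears on this only loosely: it shows that replacing one five-membered aromatic ring with 2 hetero atoms by another at this place changed little, but the ring type and substitution pattern of the entering pyrazolyl group are not covered by any measured pair, so the step could run either way. The expected step is accordingly small and of no clear direction, a 2.0-fold higher number from compound 2 to compound 3 (0.30 log units; within the scatter), with a wide range around it. Compound 3 is estimated at 40 nM in this assay, with a range from 10 nM to 160 nM.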

Compound 3, half-maximal inhibitory concentration: 83 nM
The estimate for compound 3 lay 2.1-fold (0.32 log units) below the measured number; measured number inside the range.
By their numbers in this assay, from the lowest: compounds 2 and 1 (each within the scatter of the next); then compound 3.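

At this place on a saturated chain carbon bound to an amine nitrogen in a ring, the five-membered aromatic rings with 2 hetero atoms are not interchangeable in this assay: 1,5-dimethyl-1H-pyrazol-3-yl gives a 4.2-fold higher number from compound 2 to compound 3 (0.62 log units; beyond the scatter) and a 2.2-fold higher number from compound 1 to compound 3 (0.35 log units; beyond the scatter), both modest but beyond the scatter and in the same direction, whereas the exchange between the thiazolyl and oxazolyl groups stayed within it. The counts of hydrogen-bond donors and acceptors are the same for the leaving thiazolyl and the entering pyrazolyl groups, so these counts alone do not separate compound 3 from compound 2, and the change still combines a different ring type with a different substitution pattern. No supporting data bear on the origin of this shift.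

Still open, going by these compounds, is whether the higher number belongs to the pyrazole ring itself or to the replacement of the ethyl group, as these two features change together here. A pyrazolyl group carrying an ethyl substituent would address that question, while a pyridinyl or plain phenyl ring would test whether a five-membered aromatic ring is needed at this place at all.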